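This account rests on a few compounds, and the source may have more. Where it says the series, first, only, none or still open, it means among the compounds named here.

Compound 2 `CC(C)c1ccc(NC(=O)N2CCN(c3ncccc3[N+](=O)[O-])CC2)cc1` gives 245 nM in a functional assay on HEK293 cells for antagonist activity at transient receptor potential cation channel subfamily V member 1 (Rattus norvegicus) (a lower number here means a stronger inhibitor, a higher number a weaker inhibitor), the lower of the two numbers measured; compound 1 `CC(C)(C)c1ccc(NC(=S)N2CCN(c3ncccc3C(F)(F)F)CC2)cc1` gives 441 nM in this assay, a gap that lies within the scatter, so the two stand level. Going by the values given here, compound 3 `CC(C)c1ccc(NC(=O)N2CCN(c3ncccc3Cl)CC2)cc1` carries chloro in place of nitro on an aromatic carbon, a change for which no measured step exists. Compound 3 is expected to show a step of a 1.6-fold higher number from compound 2 to compound 3 (0.21 log units; within the scatter), a small move toward a weaker inhibitor if any, not clearly beyond the scatter. Compound 3 is therefore estimated at 400 nM, in the range from 150 nM to 1200 nM.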

Compound 3, half-maximal inhibitory concentration: 17.3 nM
Compound 3: middle estimate off by 23-fold (1.36 log units), on the high side; measured number outside the range, below it.
By their numbers in this assay, from the lowest: compound 3; then compounds 2 and 1 (each within the scatter of the next).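

Moving from 3-nitropyridin-2-yl to 3-chloropyridin-2-yl gives the first step in this assay that can be read at a single place (a 14-fold lower number from compound 2 to compound 3 (1.15 log units; beyond the scatter)). It shows that the group on this aromatic carbon, two atoms from the ring nitrogen, strongly affects the read-out, with chloro giving the stronger inhibitor of this pair. The data shown offer no measurement that explains the size of this step.

From the compounds shown here alone, it remains open how a smaller halogen such as fluoro, or a methyl, methoxy or amine group, would compare with chloro at this place. Going by these compounds, it is also open whether chloro would give a similar gain on the core of compound 1.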